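Varying the aryl ether terminus of a phosphoserine lipid

The source may hold more compounds than are shown below. What is called first, only, known or untested is meant among the compounds shown, and "the series" means these compounds.

Three compounds share a phosphoserine-bearing core and differ in the group on an oxygen on an aromatic ring. Compound 1 `N[C@@H](COP(=O)(O)OCCCOC(=O)CCc1ccccc1OCCCCCCOc1ccccc1)C(=O)O` gives 0.071 in an assay on cells for activation of probable G-protein coupled receptor 34 (Mus musculus), with a stated time of 1 h; a lower number here means a smaller maximal response, a higher number a larger maximal response. Compound 2 `Cc1cccc(Oc2cccc(COc3ccccc3CCC(=O)OCCCOP(=O)(O)OC[C@H](N)C(=O)O)c2)c1` gives 0.29 in this assay, the second highest of the three numbers. Compound 3 `N[C@@H](COP(=O)(O)OCCCOC(=O)CCc1ccccc1OCc1cccc(Oc2ccc(Cl)c(Cl)c2)c1)C(=O)O` gives 0.71 in this assay, the highest. Compound 2 sits between them: compound 1 is the nearer, and compound 3 is the further.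

Compound 4 `CCc1ccc(Oc2cccc(COc3ccccc3CCC(=O)OCCCOP(=O)(O)OC[C@H](N)C(=O)O)c2)cc1` has not yet been measured in this assay. Its structural change from compound 2 is 4-ethylphenyl in place of 3-methylphenyl on an oxygen on an aromatic ring. Within the data shown here, the one measured step at this same place is a number 0.42 higher from compound 2 to compound 3 (beyond the scatter), which was large. The present change is not that one, so only a loose reading is possible. Compound 4 is therefore expected to give about 0.35, between 0.15 and 0.6. The expected step is a number 0.060 higher from compound 2 to compound 4 (within the scatter), an estimate with wide uncertainty in either direction.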

Compound 4, intrinsic activity: the largest response reached, as a fraction of the reference agonist's: 0.42
Estimate against measurement, compound 4: 0.070 below; measured number inside the range.
By their numbers in this assay, from the lowest: compound 1; then compound 2; then compound 4; then compound 3.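

Within this assay, the group on an oxygen on an aromatic ring proves sensitive even to a change that involves only carbon: 4-ethylphenyl in place of 3-methylphenyl gives a number 0.13 higher from compound 2 to compound 4 (beyond the scatter), so the movement at this position does not depend on chlorine. That gain still falls short of the 3,4-dichlorophenyl group, as 4-ethylphenyl in its place gives a number 0.29 lower from compound 3 to compound 4 (beyond the scatter), and the two chlorines therefore remain ahead of the ethyl group in this comparison. No measurement available here accounts for either step.

The step from compound 2 to compound 4 alters both the alkyl group and where it sits on the ring, and the compounds shown do not separate these two changes. As far as these compounds go, how a ring carrying an amine or a carboxylic acid at this terminus would compare remains open.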